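A few compounds are considered here, and "the series" means these few. Any claim that something is new, unique, unknown or untested is made for them only; others in the source may bear on it.

Compound 1 `CN1[C@@H]2c3[nH]c4ccccc4c3C[C@H]1[C@H](C#N)N1[C@@H](CN3C(=O)c4ccccc4C3=O)c3[nH]c4ccccc4c3C[C@@H]21`: 410 nM
Compound 2 `CN1[C@@H]2c3[nH]c4ccccc4c3C[C@H]1[C@H](C#N)N1[C@@H](CNC(=O)c3ccc(Cl)cc3)c3[nH]c4ccccc4c3C[C@@H]21`: 110 nM

Within the data shown here, in a functional assay on BGC-823 cells (Homo sapiens) for cytotoxicity, read by MTT assay, with a stated time of 72 h (a lower number here means a stronger inhibitor, a higher number a weaker inhibitor), compound 2 gives the lowest of the two numbers, and the single measured step, a 3.7-fold lower number from compound 1 to compound 2 (0.57 log units; beyond the scatter), separates it from compound 1. Compound 3 `COc1ccc(C(=O)NC[C@H]2c3[nH]c4ccccc4c3C[C@H]3[C@H]4c5[nH]c6ccccc6c5C[C@@H]([C@H](C#N)N23)N4C)cc1` keeps the amide of compound 2 and changes only the aromatic substituent: methoxy in place of chloro on an aromatic carbon. Among the measured compounds shown here, no measured step touches this position, so the step from compound 1 to compound 2 gives no direct guidance. Compound 3 is therefore expected to stay close to compound 2, with a step of a 1.4-fold higher number from compound 2 to compound 3 (0.13 log units; within the scatter) that lies within the scatter. The estimate for compound 3 is 150 nM, with a range from 60 nM to 400 nM.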

Compound 3, half-maximal inhibitory concentration: 320 nM
Beside the measured number, compound 3's estimate is 2.1-fold (0.33 log units) below it; the range from low to high includes it.
By their numbers in this assay, from the lowest: compound 2; then compounds 3 and 1 (each within the scatter of the next).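

In this assay, the change from 4-chlorophenyl to 4-methoxyphenyl on the amide gives a 2.9-fold higher number from compound 2 to compound 3 (0.46 log units; beyond the scatter), so this aromatic position responds to its substituent. With methoxy in place, a 1.3-fold lower number from compound 1 to compound 3 (0.11 log units; within the scatter) lies within the scatter, so the amide alone does not separate the side chains of these compounds; the gain seen in compound 2 depends on the chloro. Nothing available explains this difference.

The compounds shown leave open whether the step follows from chloro itself or from the loss of methoxy. An unsubstituted phenyl, a fluoro or an amine at this position could separate these readings.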